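The source may report more compounds than this note shows. Statements on the series, on what has been measured and on what is new or still open speak of the compounds shown alone.

Of the compounds shown here, two sharing one core have been measured so far. Compound 1 `COc1ccc(NC(=S)NC(=O)c2cn(-c3ccccc3)nc2-c2ccc(OC)cc2)cc1` carries a (4-methoxyphenyl)amino group on its thiourea, while compound 2 `Cc1ccc(NC(=S)NC(=O)c2cn(-c3ccccc3)nc2-c2ccccc2)cc1` is built on the same core with a different pattern of substituents. In a functional assay on A549 cells (Homo sapiens) for inhibition, read by CCK-8 assay, with a stated time of 48 h (on this read-out lower numbers stand for stronger inhibition and higher numbers for weaker inhibition), compound 1 gives 750 nM, the lower of the two numbers, and in this assay compound 2 gives 2800 nM. The gap between them lies beyond the scatter, but the two compounds differ in more than one place, so it cannot be tied to any single change.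

Compound 3 `COc1ccc(-c2nn(-c3ccccc3)cc2C(=O)NC(=S)Nc2ccc(Cl)cc2)cc1` has not yet been measured. It differs from compound 1 in one place only: chloro in place of methoxy on an aromatic carbon. For the measured compounds named here, no measured pair shows this exchange on its own, so there is no measured step to lean on, and the closest guide is simply the number for compound 1. The step from compound 1 to compound 3 is expected to be small, a 1.2-fold lower number from compound 1 to compound 3 (0.06 log units; within the scatter), with no clear direction beyond the scatter. On that basis compound 3 is expected to give about 650 nM in this assay, with a likely range from 250 nM to 1800 nM.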

Compound 3, half-maximal inhibitory concentration: 1310 nM
For compound 3 the middle estimate is 2.0-fold (0.30 log units) below the measured one; low and high end bracket the measured number.
By their numbers in this assay, from the lowest: compounds 1 and 3 (each within the scatter of the next); then compound 2.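

In this assay, for the compounds shown here, the exchange of methoxy for chloro on the thiourea side, from (4-methoxyphenyl)amino to (4-chlorophenyl)amino, gives a 1.7-fold higher number from compound 1 to compound 3 (0.24 log units; within the scatter) and is the first step that changes one place only. This position therefore accepts either group without a change that can be told from the ordinary variation between repeated measurements, even though the exchange swaps two heavy atoms for one and removes the hydrogen-bond acceptor counted on the methoxy group. The methoxy group on the other 4-methoxyphenyl ring stays in place across this step, so the result speaks only for the ring on the thiourea, and nothing measured here bears on why the two groups read alike.

The compounds shown leave open whether this tolerance extends to very different groups on the same aromatic carbon, such as an amine, a carboxylic acid or a longer chain like butoxy. They also leave open whether removing the substituent altogether, with a hydrogen on that carbon, would keep the number in the same range.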